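Sulfonamide series: alkyl replacement for cyclohexyl on the aniline ring

A few compounds are considered here, and "the series" means these few. Any claim that something is new, unique, unknown or untested is made for them only; others in the source may bear on it.

Measured so far:
- compound 1, `CCc1ccccc1NS(=O)(=O)c1ccc(N2CCNC2=O)cc1`: 350 nM
- compound 2, `O=C1NCCN1c1ccc(S(=O)(=O)Nc2ccc(C3CCCCC3)cc2)cc1`: > 1000 nM
- compound 3, `O=C1NCCN1c1ccc(S(=O)(=O)Nc2cccc(Oc3ccccc3)c2)cc1`: 220 nM

In a functional assay on MCF7 cells (Homo sapiens) for antiproliferative activity, read by sulforhodamine B assay, with a stated time of 48 h (a lower number here means a stronger inhibitor, a higher number a weaker inhibitor), compound 1 gives 350 nM and compound 3 gives 220 nM. For compound 2 the value > 1000 nM is a limit of this assay and not a number, as noted in the limit of > 1000 nM in this assay, at which 1 of the 3 values shown sits; compound 2 therefore stands at the weak end of the three compounds shown, with no exact figure.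

Compound 4, `CCCCc1ccc(NS(=O)(=O)c2ccc(N3CCNC3=O)cc2)cc1`, is not yet measured in this assay. It differs from compound 2 in one place: butyl in place of cyclohexyl on an aromatic carbon

Among the compounds with values here, no measured pair differing in one place is available, so the size of this step can only be guessed. Within the data shown here, compound 2 is the only compound carrying a cyclohexyl and the only one at the limit, so the butyl is expected to bring compound 4 back toward a measurable value; the step of an at least 1.2-fold lower number from compound 2 to compound 4 (0.09 log units; that floor lies within the scatter) is expected to run toward stronger inhibition, but with wide uncertainty and with a real chance that compound 4 also ends at the limit. Compound 4 is estimated at 800 nM, in a range from 250 nM to 3000 nM.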

Compound 4, half-maximal inhibitory concentration: 770 nM
For compound 4 the middle estimate is 1.0-fold (0.02 log units) above the measured one; the measured number falls inside the stated range.
By their numbers in this assay, from the lowest: compounds 3 and 1 (each within the scatter of the next); then compound 4. At a limit, above all of these: compound 2.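

With butyl on the aromatic carbon para to a large group, this position gives its first measured number: in this assay compound 4 gives 770 nM in the antiproliferative read-out. For compound 2, the > 1000 nM is a limit of the assay and not a number. Butyl in place of cyclohexyl therefore reads as an at least 1.2-fold lower number from compound 2 to compound 4 (0.11 log units; that floor lies within the scatter) and sets only a floor on the step, not its true size, so the change cannot yet be said to go beyond the scatter.

The compounds shown do not separate the effect of chain length from that of losing the ring. A longer chain such as hexyl, or a butyl ending in an amine or a carboxylic acid, would show how the number at this position follows the group placed there.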